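Working notes: methoxy for methylsulfanyl on the aryl ring

The source may report more compounds than this note shows. Statements on the series, on what has been measured and on what is new or still open speak of the compounds shown alone.

Measured so far:
compound 1 `CCN(c1ccc(OC)cc1)c1ncnc2occ(C)c12`, 8.1 nM
compound 2 `CSc1ccc(N(C)c2ncnc3occ(C)c23)cc1`, 12.3 nM

In a functional assay on MDA-MB-435 cells (Homo sapiens) for inhibition, read by sulforhodamine B assay, with a stated time of 48 h (a lower number here means that less compound is needed, a higher number that more compound is needed for the effect), compound 2 gives 12.3 nM, the higher of the two numbers; its nearest neighbour is compound 1 at 8.1 nM, and that gap lies within the scatter. Compound 3 `COc1ccc(N(C)c2ncnc3occ(C)c23)cc1` has not been measured; it differs from compound 2 by methoxy in place of methylsulfanyl on an aromatic carbon. For the measured compounds named here, no step between measured compounds covers this change, so the expectation is for no shift beyond the scatter, in either direction. Compound 3 is expected at 9 nM, with a range from 4 nM to 22 nM. The expected step is a 1.4-fold lower number from compound 2 to compound 3 (0.14 log units; within the scatter).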

Compound 3, half-maximal effective concentration: 4.3 nM
For compound 3 the middle estimate is 2.1-fold (0.32 log units) above the measured one; the measured number falls inside the stated range.
By their numbers in this assay, from the lowest: compounds 3, 1 and 2 (each within the scatter of the next, the first and the last beyond it).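

In this assay methoxy in place of methylsulfanyl on an aromatic carbon, para to a large group, gives a modest step beyond the scatter (a 2.9-fold lower number from compound 2 to compound 3 (0.46 log units; beyond the scatter)). Hydrogen in place of methyl on the saturated chain carbon bound to the nitrogen stays within the scatter (a 1.9-fold lower number from compound 1 to compound 3 (0.28 log units; within the scatter)), so this change shows no clear effect. No measurement here accounts for the methoxy step.

The compounds shown leave open how an amine or a longer chain such as ethoxy would fare at this ring position. They also leave open whether the methoxy step holds with ethyl on the nitrogen.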